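Sulfonamide series: the step from compound 2 to compound 3

This account rests on a few compounds, and the source may have more. Where it says the series, first, only, none or still open, it means among the compounds named here.

- Compound 1 `O=S(=O)(Nc1ccccc1Cl)c1ccc(-c2cnc(C3CC3)o2)cc1`: > 100000 nM
- Compound 2 `Cc1ccc(Cl)c(NS(=O)(=O)c2ccc(-c3cnc(C4CC4)o3)cc2)c1`: > 100000 nM

In a functional assay on cells (leukaemia cell line, Homo sapiens) for inhibition, read by sulforhodamine B assay, with a stated time of 48 h (a higher number here means that more compound is tolerated, a lower number that less compound is tolerated), compound 2 gives > 100000 nM, which is a limit and not a number. Compound 1 also gives only a limit, > 100000 nM. For the measured compounds named here, the sole measured step is a step that the two limits leave unreadable from compound 1 to compound 2. Going by the values given here, the series so far offers only (the limit of > 100000 nM in this assay, at which 2 of the 2 values shown sit).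

Compound 3 `Cc1cc(Cl)cc(NS(=O)(=O)c2ccc(-c3cnc(C4CC4)o3)cc2)c1` has 3-chloro-5-methylphenyl in place of 2-chloro-5-methylphenyl on a sulfonamide nitrogen. With no readable step size, no change beyond the scatter is expected. The estimated step is a number no higher from compound 2 to compound 3 (the limit leaves the size open). In this assay the expected value for compound 3 is 100000 nM, with an estimated range of 30000 nM to 200000 nM.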

Compound 3, concentration lethal to 50% of the cells: 84900 nM
Estimate against measurement, compound 3: 1.2-fold (0.07 log units) above; low and high end bracket the measured number.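

For the compounds shown here, with 3-chloro-5-methylphenyl in place of 2-chloro-5-methylphenyl on a sulfonamide nitrogen, this assay returns a readable number for the first time, with an at least 1.1-fold lower number from compound 2 to compound 3 (0.07 log units; that floor lies within the scatter). Against 3-chloro-5-methylphenyl in place of 2-chlorophenyl, the reading is the same, with an at least 1.1-fold lower number from compound 1 to compound 3 (0.07 log units; that floor lies within the scatter). Both steps are only floors that lie within the scatter, so their true size stays open, and most of the series still rests on a limit: the limit of > 100000 nM in this assay, at which 2 of the 3 values shown sit.

On these data alone, whether an amine or a carboxylic acid on the phenyl group at this sulfonamide nitrogen would give a clearly lower number stays open.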